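The compounds below may be only part of what the source reports. "The series", "measured", "known", "first", "only" and "open" are said of these compounds alone.

For the measured compounds named here, in a functional assay on MT2 cells (Homo sapiens) for cytotoxicity, read by MTT assay (on this read-out higher numbers stand for lower toxicity in this test and lower numbers for higher toxicity in this test), three compounds have numbers so far. Compound 3 (`Clc1ccc(Nc2nccs2)cc1OCc1nccs1`) gives 20000 nM and stands within the scatter of compound 1 (`N#Cc1ccc(Nc2nccs2)cc1OCc1ccco1`) with 18000 nM while compound 2 (`N#Cc1ccc(Nc2nccs2)cc1OCc1ccsc1`) with 1100 nM lies far lower on the scale of this assay and so is the more toxic in this test.

Compound 4 (`N#Cc1ccc(Nc2nccs2)cc1OCc1nccs1`) is the next to be read. It departs from compound 3 by one change, cyano in place of chloro on an aromatic carbon.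

Going by the values given here, no measured step covers this exchange. Among the compounds with values here, the only measured step (a 16-fold lower number from compound 1 to compound 2 (1.21 log units; beyond the scatter)) is large, but it replaces furan-2-yl with thiophen-3-yl on a saturated chain carbon bound to an oxygen, and cyano is present on both sides of it. That step shows that the number can move strongly with cyano in place, so cyano alone does not fix the value. Within the data shown here, compound 4 keeps the ring of compound 3 at that chain carbon, and no measured compound pairs that ring with cyano.

A modest move towards a lower number is therefore expected, and a result within the scatter would be no surprise. The estimated move is a 2.2-fold lower number from compound 3 to compound 4 (0.35 log units; beyond the scatter) and nothing larger is assumed. Compound 4 is expected near 9000 nM (estimated range 2000 nM to 30000 nM).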

Compound 4, half-maximal cytotoxic concentration: 20000 nM
Compound 4: the middle estimate sits 2.2-fold (0.35 log units) below what was measured; measured number inside the range.
By their numbers in this assay, from the lowest: compound 2; then compounds 1, 3 and 4 (each within the scatter of the next).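

In this assay, the exchange of chloro for cyano on the aromatic carbon para to the (1,3-thiazol-2-yl)amino group gives no change at the digits printed from compound 3 to compound 4 (within the scatter), so with 1,3-thiazol-2-yl on the chain carbon, the number does not separate these two groups at this position. Among the cyano compounds, the ring on the chain carbon can matter far more: the series shows an 18-fold higher number from compound 2 to compound 4 (1.26 log units; beyond the scatter), yet also a 1.1-fold higher number from compound 1 to compound 4 (0.05 log units; within the scatter), so thiophen-3-yl stands apart while furan-2-yl and 1,3-thiazol-2-yl do not separate from each other. No evidence is available that bears on the reason for either result.

Chloro appears here only with 1,3-thiazol-2-yl on the chain carbon, so it remains open whether the exchange for cyano would also leave the number unmoved with thiophen-3-yl, the one ring that gives the lower number. The compounds shown also leave open how an amine, a carboxylic acid or a methoxy group on this aromatic carbon would read in this assay, and whether any such group would move the number at all.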